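Swapping chloro for methoxy on compound 2

This account rests on a few compounds, and the source may have more. Where it says the series, first, only, none or still open, it means among the compounds named here.

In an ADME assay on J774.A1 cells (Mus musculus) for cytotoxicity, read by MTT assay, with a stated time of 72 h (a lower number here means that less compound is tolerated, a higher number that more compound is tolerated), compound 2 `CC1(c2ccc(NC(c3ccc(Cl)cc3)c3nnnn3C(C)(C)C)cc2)NC(=O)c2ccccc2N1` gives > 400000 nM as a limit of the assay and not as a number. Going by the values given here, compound 2 stands at the limit of > 400000 nM in this assay, at which 1 of the 3 values shown sits, and no compound in this small set has a single number yet. The entry for compound 1 `COc1cc(C(Nc2ccc(C3(C)NC(=O)c4ccccc4N3)cc2)c2nnnn2C(C)(C)C)cc(OC)c1OC` reads "not determined" (no result reported) and the entry for compound 3 `CC1(c2ccc(Nc3nc(Nc4ccccc4)nc(Nc4ccccc4)n3)cc2)NC(=O)c2ccccc2N1` reads "not determined" (no result reported) so neither offers a comparison.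

The next compound to be measured is compound 4 `COc1ccc(C(Nc2ccc(C3(C)NC(=O)c4ccccc4N3)cc2)c2nnnn2C(C)(C)C)cc1` which keeps the rest of compound 2 and alters one group. A methoxy stands in place of chloro on an aromatic carbon, turning 4-chlorophenyl into 4-methoxyphenyl (methoxy in place of chloro on an aromatic carbon).

Among the compounds with values here, no pair of measured compounds differs in one place, so the data hold no earlier step to borrow from. Within the data shown here, the expectation therefore rests on compound 2 alone, with its limit of > 400000 nM as the only reading. No change beyond the usual scatter is expected, and neither direction is favoured. Estimated in those terms, the expected change is an at least 1.1-fold lower number from compound 2 to compound 4 (0.05 log units; that floor lies within the scatter) and it may not be resolved at all, since the assay may again report only a limit. For compound 4 the estimated value is 350000 nM with an expected range from 150000 nM to 600000 nM if a number is reported.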

Compound 4, half-maximal cytotoxic concentration: > 400000 nM
Compound 4 was reported as a limit; the forecaster's own chance of this, stated with the estimate: 70%; middle value at least 1.1-fold (0.05 log units) from the limit.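

Compound 2 and compound 4 are both reported only as a limit, so no step can be read from the change of chloro to methoxy: the limit of > 400000 nM in this assay, at which 2 of the 4 values shown sit.

The compounds shown leave open whether 4-chlorophenyl and 4-methoxyphenyl differ at all in this cell test, and at what concentration either compound would begin to harm the cells.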